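Swapping the Pyridinyl Ring of Compound 1 for Methoxyphenyl

The source may report more compounds than this note shows. Statements on the series, on what has been measured and on what is new or still open speak of the compounds shown alone.

Compound 1 `O=C(O)c1ccc(CN2C(=O)S/C(=C\c3cccnc3)C2=O)cc1` was examined in a functional assay on HeLa cells (Homo sapiens) for cytotoxicity, read by MTT assay, with a stated time of 24 h (on this read-out lower numbers stand for stronger inhibition and higher numbers for weaker inhibition), where compound 1 gives 88000 nM. Of the three measured numbers this is the highest, yet both other compounds sit within the usual scatter of it, so no real order among them can be read. Compound 2 `O=C(O)c1ccc(CN2C(=O)S/C(=C\c3ccccn3)C2=O)cc1` gives 62000 nM in this assay, and compound 3 `Cc1ccc(/C=C2\SC(=O)N(Cc3ccc(C(=O)O)cc3)C2=O)cc1` gives 68000 nM.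

Compound 4 `COc1ccc(/C=C2\SC(=O)N(Cc3ccc(C(=O)O)cc3)C2=O)cc1` differs from compound 1 in a single place: 4-methoxyphenyl in place of pyridin-3-yl on a double-bonded chain carbon bound to a double-bonded ring carbon. Going by the values given here, two measured steps bear on this exchange, since each replaces the same pyridin-3-yl with another six-membered aromatic ring at the same place. These steps gave a 1.4-fold lower number from compound 1 to compound 2 (0.15 log units; within the scatter) and a 1.3-fold lower number from compound 1 to compound 3 (0.11 log units; within the scatter), and neither rises above the scatter. The step to compound 3 is the closer guide, because it also brings in a six-membered aromatic ring of carbon only and gave a 1.3-fold lower number from compound 1 to compound 3 (0.11 log units; within the scatter). On that basis no step beyond the scatter is expected in this assay, in either direction.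

For compound 4 the expected value in this assay is therefore estimated at 72000 nM. The range expected for compound 4 runs from 36000 nM to 144000 nM. This estimate corresponds to an expected step of a 1.2-fold lower number from compound 1 to compound 4 (0.09 log units; within the scatter).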

Compound 4, half-maximal inhibitory concentration: 40000 nM
Compound 4: middle estimate off by 1.8-fold (0.26 log units), on the high side, and the stated range covers the measured number.
By their numbers in this assay, from the lowest: compounds 4, 2, 3 and 1 (each within the scatter of the next, the first and the last beyond it).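

Going by these compounds alone, the exchange of pyridin-3-yl for 4-methoxyphenyl gave a 2.2-fold lower number from compound 1 to compound 4 (0.34 log units; beyond the scatter) in this assay and is the first step at this place to clear the scatter, though only modestly. The other two steps into compound 4 stay inside it: methoxy in place of methyl on an aromatic carbon gave a 1.7-fold lower number from compound 3 to compound 4 (0.23 log units; within the scatter) and 4-methoxyphenyl in place of pyridin-2-yl gave a 1.6-fold lower number from compound 2 to compound 4 (0.19 log units; within the scatter) so the numbers set compound 4 apart from compound 1 but not from compound 2 or compound 3. The place on the double-bonded chain carbon therefore responds to the ring it carries, at least for this one pair of groups, but nothing available here accounts for that difference.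

The compounds shown leave open how this place would respond if the 4-methoxyphenyl ring carried a hydroxy group, a chlorine atom or a dimethylamino group instead of methoxy. They also leave open whether the step between compound 1 and compound 4 would hold if an amide took the place of the carboxylic acid on the benzyl part of the shared core.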